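This account rests on a few compounds, and the source may have more. Where it says the series, first, only, none or still open, it means among the compounds named here.

The series shares one core, first seen in compound 1 `Cc1ccc2c(c1)C(=O)/C(=C/c1ccccc1)CN2CC(=O)O`. In an assay on HL-60 cells for inhibition of glutathione S-transferase P (Homo sapiens), read by spectrophotometry, tested at 20 uM (a lower number here means less inhibition, a higher number more inhibition at the concentration tested (going by the name of the read-out)), compound 1 gives 4.23%. Within the data shown here, compound 2 `Cc1ccc2c(c1)C(=O)/C(=C/c1ccc(F)cc1)CN2CC(=O)O` differs from it by fluoro in place of hydrogen on an aromatic carbon; in this assay compound 2 gives 16.1%, the highest of the two numbers so far, with compound 1 the nearest and lower. Among the measured compounds shown here, the only step measured is a number 11.9 percentage points higher from compound 1 to compound 2 (beyond the scatter).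

Compound 3 `CCOc1ccc(/C=C2\CN(CC(=O)O)c3ccc(C)cc3C2=O)cc1` is the next member. Relative to compound 2 the change is ethoxy in place of fluoro on an aromatic carbon. For the measured compounds named here, the step from compound 1 to compound 2 is the only one that concerns this place on the ring, and it was modest; it shows that a substituent there can raise the read-out, but says nothing about exchanging one substituent for another, and no measured pair involves an ethoxy at all. The expected step in this assay is therefore a number 1.9 percentage points higher from compound 2 to compound 3 (within the scatter), small and open in direction. Compound 3 is estimated at 18%, with a range of 4% to 36%.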

Compound 3, a percentage reported as inhibition, at one concentration (the size of the read-out at that concentration, not a potency): 25.8%
Compound 3: the middle estimate sits 7.8 percentage points below what was measured; the range from low to high includes it.
By their numbers in this assay, from the lowest: compound 1; then compounds 2 and 3 (each within the scatter of the next).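

In this assay the exchange of fluoro for ethoxy at this place on the aromatic ring gives a step within the scatter (a number 9.7 percentage points higher from compound 2 to compound 3 (within the scatter)), so the two substituents cannot be told apart here, although ethoxy enters with 3 heavy atoms and 1 hydrogen-bond acceptor where fluoro has 1 heavy atom and none. Compared with hydrogen, this place now carries a second substituent with a step beyond the scatter (a number 21.6 percentage points higher from compound 1 to compound 3 (beyond the scatter)), so both fluoro and ethoxy, para to a large group, go with a higher read-out than compound 1, a statement limited to these three compounds. Nothing measured here accounts for this outcome or gives a property of either group that bears on it.

Still open, from the compounds shown here alone, is whether another group at this place, such as an amine, a carboxylic acid or a longer alkoxy chain, would stand clear of the scatter from both compound 2 and compound 3. Also open, going by these compounds, is how the read-out responds to changes elsewhere on the shared core, which stays the same in all three compounds, and a single tested concentration gives no potency for any of them.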